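Changing the nitrogen substituent: compound 2 to compound 3

The compounds below may be only part of what the source reports. "The series", "measured", "known", "first", "only" and "open" are said of these compounds alone.

- Compound 1 `COc1cc(C(=O)c2ccc3cc[nH]c3c2)cc(OC)c1OC` – 430 nM
- Compound 2 `COc1cc(C(=O)c2ccc3c(ccn3C(C)C)c2)cc(OC)c1OC` – 1100 nM

In a functional assay on TSGH cells (Homo sapiens) for inhibition, with a stated time of 72 h (a lower number here means a stronger inhibitor, a higher number a weaker inhibitor), compound 2 holds the higher of the two numbers and is the weaker by a margin beyond the scatter. Compound 3 `COc1cc(C(=O)c2ccc3c(ccn3CCN(C)C)c2)cc(OC)c1OC` is not yet measured. It carries 2-(dimethylamino)ethyl in place of isopropyl on an aromatic nitrogen. Among the measured compounds shown here, no measured pair isolates a change at this place, so the expectation is loose: no step beyond the scatter in this assay is expected. The expected step is a 1.1-fold higher number from compound 2 to compound 3 (0.04 log units; within the scatter) and it stays small. The estimate for compound 3 is 1200 nM with an expected range of 350 nM to 4000 nM and little evidence behind it.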

Compound 3, half-maximal inhibitory concentration: 4900 nM
Compound 3: middle estimate off by 4.1-fold (0.61 log units), on the low side, outside the stated range (above it).
By their numbers in this assay, from the lowest: compound 1; then compound 2; then compound 3.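

In this assay, 2-(dimethylamino)ethyl in place of isopropyl on the aromatic nitrogen gives a 4.5-fold higher number from compound 2 to compound 3 (0.65 log units; beyond the scatter) as a modest weakening. Among the compounds shown here, this is the first step read at this place, and it shows that the group on this nitrogen matters: the longer, nitrogen-bearing chain is not tolerated as well as isopropyl. No supporting data bear on what lies behind this step.

Open, as far as these compounds go, is whether a plain butyl chain of similar length would give the same step, which would separate chain length from the amine. A 2-hydroxyethyl or morpholinoethyl group on this nitrogen also remains to be compared.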